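A few compounds are considered here, and "the series" means these few. Any claim that something is new, unique, unknown or untested is made for them only; others in the source may bear on it.

Compound 1 `Cc1ccc2c(=O)[nH]c(-c3cccc(OC(F)(F)F)c3)nc2c1` is the reference point for this step. For the measured compounds named here, in an assay on isolated protein for inhibition of DNA topoisomerase 1 (Homo sapiens), with a stated time of 30 min, tested at 100 uM (a higher number here means a stronger effect of the compound at the concentration tested, a lower number a weaker effect), compound 1 gives 77.2%, the lower of the two numbers measured so far. Going by the values given here, the only comparison is compound 2 `Cc1ccc2c(=O)[nH]c(-c3cccc4ccccc34)nc2c1`, which in this assay gives 100%, a value that lies beyond the scatter above compound 1. Among the compounds with values here, no pair of measured compounds differs in a single place, so no measured step guides the change considered here.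

Compound 3 `Cc1ccc2c(=O)[nH]c(-c3cccc(C(F)(F)F)c3)nc2c1` is the unmeasured target. The change from compound 1: trifluoromethyl in place of trifluoromethoxy on an aromatic carbon. Both groups carry the same fluorines; what leaves is the oxygen of the trifluoromethoxy. With no measured step of this kind in this assay, the step is expected to be small, of no clear direction, and likely within the scatter. The estimated step is a number 5.2 percentage points lower from compound 1 to compound 3 (within the scatter). Compound 3 is expected to give 72% in this assay, with a range from 50% to 92%.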

Compound 3, a percentage reported as inhibition, at one concentration (the size of the read-out at that concentration, not a potency): 100%
The estimate for compound 3 lay 28 percentage points below the measured number, outside the stated range (above it).
By their numbers in this assay, from the lowest: compound 1; then compounds 2 and 3 (each within the scatter of the next).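

Trifluoromethyl in place of trifluoromethoxy on an aromatic carbon gives a number 22.8 percentage points higher from compound 1 to compound 3 (beyond the scatter) in this assay, the first step in the series that changes one place only. This position is therefore not indifferent to the change, and loss of the oxygen of the trifluoromethoxy is the only structural difference within this pair. The step rests on a single pair at a single concentration, and no measurement at hand bears on why the two groups differ.

As far as these compounds go, whether the step belongs to trifluoromethyl itself or extends to other groups on this carbon remains open, for example methoxy, a chlorine atom, an amine or a carboxylic acid. Also open, from the compounds shown here alone, is whether the same change would give a similar step on a different core.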